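Swapping the Thiophene of Compound 1 for Pyridine

The source may hold more compounds than are shown below. What is called first, only, known or untested is meant among the compounds shown, and "the series" means these compounds.

Compound 1 `COC(=O)c1sc2cc(-c3ccsc3)cnc2c1N`: 12400 nM
Compound 2 `COC(=O)c1sc2cc(-c3ccc(-c4cccs4)s3)cnc2c1N`: 700 nM
Compound 3 `COC(=O)c1sc2cc(-c3ccoc3)cnc2c1N`: > 120000 nM

Of the compounds shown here, three sharing one core have been measured in a functional assay on NCI-H460 cells (Homo sapiens) for inhibition, read by sulforhodamine B assay, with a stated time of 48 h; on this read-out lower numbers stand for stronger inhibition of growth and higher numbers for weaker inhibition of growth. Among the two numbered results, compound 1 stands highest, and compound 2 sits clearly below it, beyond the usual scatter. Compound 3 gives only a limit of this assay, (the limit of > 120000 nM in this assay, at which 1 of the 3 values shown sits), and no number. The only single-point change among these measured compounds is the one from compound 1 to compound 3, which produced an at least 9.6-fold higher number from compound 1 to compound 3 (0.98 log units; beyond the scatter), a swap of one five-membered ring for another.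

Compound 4 `COC(=O)c1sc2cc(-c3cccnc3)cnc2c1N` has not yet been measured. It differs from compound 1 in one place: pyridin-3-yl in place of thiophen-3-yl on an aromatic carbon. The step from compound 1 to compound 3 is the one that bears on this change, since it also exchanges the thiophen-3-yl at the same place; that step went toward weaker inhibition and was at least modest. A further loss is therefore expected for compound 4, of a size near a 3.2-fold higher number from compound 1 to compound 4 (0.51 log units; beyond the scatter). Compound 4 is expected to give about 40000 nM, with a range from 8000 nM to 120000 nM.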

Compound 4, concentration for 50% growth inhibition: > 112000 nM
Compound 4 ended at the assay's limit; the forecaster's own chance of this, stated with the estimate: 30%; middle value at least 2.8-fold (0.44 log units) from the limit.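

Replacing thiophen-3-yl with pyridin-3-yl gave an at least 9.0-fold higher number from compound 1 to compound 4 (0.95 log units; beyond the scatter) in this assay, so a second ring exchange at this position, now to a six-membered aromatic ring, also went toward weaker inhibition of growth. Compound 4 gives only a limit of this assay and no number: the limit of > 112000 nM in this assay, at which 1 of the 4 values shown sits. Among the compounds shown, only compound 1 and compound 2, which both carry thiophene rings at this carbon, give numbers, while the furan-3-yl and pyridin-3-yl groups of compound 3 and compound 4 both end at limits.

From the compounds shown here alone, the step from compound 3 to compound 4 cannot be read, so the order of these two groups stays open. Also open, going by these compounds, is whether a phenyl ring, or a pyridin-3-yl ring carrying an amine, would bring a number back at this carbon.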